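This account rests on a few compounds, and the source may have more. Where it says the series, first, only, none or still open, it means among the compounds named here.

Measured in an ADME assay on MCF7 cells (Homo sapiens) for inhibition; a higher number here means a weaker inhibitor, a lower number a stronger inhibitor:
- compound 1 `COC(=O)c1cc2c(F)c(F)c(-n3ccnc3)c(F)c2s1`: > 100000 nM, a limit
- compound 2 `COC(=O)c1cc2c(F)c(F)c(-n3cnc4ccccc43)c(F)c2s1`: > 12000 nM, a limit
- compound 3 `COC(=O)c1cc2c(F)c(F)c(Sc3ccc(C(C)(C)C)cc3)c(F)c2s1`: > 50000 nM, a limit

None of the three compounds has a number in this assay. Going by the values given here, each value is a limit of the assay, so the three cannot be ranked against one another and no step between them can be read.

Compound 1 stands at a limit of > 100000 nM. No measured number marks its place.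

Compound 4 `COC(=O)CSc1c(F)c(F)c2cc(C(=O)OC)sc2c1F` keeps the core of compound 1 and has not yet been measured. It carries ((methoxycarbonyl)methyl)sulfanyl in place of 1H-imidazol-1-yl on an aromatic carbon, ortho to two fluoro groups (((methoxycarbonyl)methyl)sulfanyl in place of 1H-imidazol-1-yl on an aromatic carbon).

Among the compounds with values here, no measured step shows what a change at this place does in this assay, so the expectation rests only on the three limits. With no number among compound 1, compound 2 and compound 3, compound 4 is expected to show no clear inhibition as well, and most likely to be reported as a limit too. The expected step is an at least 1.6-fold lower number from compound 1 to compound 4 (0.22 log units; that floor lies within the scatter), a change estimated to stay within the scatter. For compound 4 the estimated value is 60000 nM, with an expected range from 12000 nM to 100000 nM.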

Compound 4, half-maximal inhibitory concentration: > 25000 nM
Compound 4 ended at the assay's limit; the forecaster's own chance of this, stated with the estimate: 80%; the middle value lies beyond the limit too.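

In this assay compound 4 gives > 25000 nM, a limit and not a number. Going by these compounds alone, compound 1 also stands at a limit, so no step from compound 1 to compound 4 can be read. The compounds shown leave open whether ((methoxycarbonyl)methyl)sulfanyl in place of 1H-imidazol-1-yl changes the read-out at all, and what concentration any of these compounds would need for half-maximal inhibition.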